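A few compounds are considered here, and "the series" means these few. Any claim that something is new, unique, unknown or untested is made for them only; others in the source may bear on it.

Measured in a functional assay on BV-2 cells (Mus musculus), read by Griess assay, with a stated time of 24 h; on this read-out higher numbers stand for weaker inhibition and lower numbers for stronger inhibition:
- compound 1 `O=C1C=CC2(C=C1)OCC(Cc1ccc(F)cc1)C(=O)N2c1ccccc1`: 400 nM
- compound 2 `O=C1C=CC2(C=C1)OCC(Cc1ccccc1CS(=O)(=O)c1ccccc1)C(=O)N2c1ccccc1`: 980 nM
- compound 3 `O=C1C=CC2(C=C1)OCC(Cc1cc(C(F)(F)F)cc(C(F)(F)F)c1)C(=O)N2c1ccccc1`: 70 nM

Compound 1 holds the middle place of these three numbers: compound 2 reads higher and compound 3 reads lower, both gaps beyond the usual scatter. Compound 4 `Cc1cc(C)cc(CC2COC3(C=CC(=O)C=C3)N(c3ccccc3)C2=O)c1` is still unmeasured. It carries 3,5-dimethylphenyl in place of 4-fluorophenyl on a saturated chain carbon bound to a saturated ring carbon. Going by the values given here, no measured pair differs in one place only, so the guide is thin. Compound 3, with two trifluoromethyl groups on its phenyl ring, gives 70 nM, which hints at a lower number for a ring bearing two groups. The expected step is modest, towards stronger inhibition: a 2.0-fold lower number from compound 1 to compound 4 (0.30 log units; within the scatter). Compound 4 is estimated at 200 nM, within an expected range of 60 nM to 600 nM.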

Compound 4, half-maximal inhibitory concentration: 1820 nM
The estimate for compound 4 lay 9.1-fold (0.96 log units) below the measured number; the measured number lies above the stated range.
By their numbers in this assay, from the lowest: compound 3; then compound 1; then compounds 2 and 4 (each within the scatter of the next).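

Placing 3,5-dimethylphenyl where compound 1 has 4-fluorophenyl gives a 4.6-fold higher number from compound 1 to compound 4 (0.66 log units; beyond the scatter) in this assay, so this saturated chain carbon is sensitive to the group it carries. Two groups on the phenyl ring do not by themselves go with a low number: compound 4 gives 1820 nM here while compound 3, with two trifluoromethyl groups, gives 70 nM in the same assay. From the compounds shown here alone, how a phenyl ring bearing an amine or a carboxylic acid would read remains open. So does the cause of this step, since no supporting measurement is available.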